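A few compounds are considered here, and "the series" means these few. Any claim that something is new, unique, unknown or untested is made for them only; others in the source may bear on it.

Measured so far in a functional assay (ileum) for inhibition, with Cavia porcellus as the target; a higher number here means a weaker inhibitor, a lower number a stronger inhibitor:
- compound 1 `CC(C)Nc1nc(O)c2cc(Cl)ccc2n1` gives 74100 nM
- compound 2 `CCC(C)Nc1nc(O)c2cc(Cl)ccc2n1` gives 44700 nM
- compound 3 `Oc1nc(NCc2ccccc2)nc2ccc(Cl)cc12` gives 13300 nM

Compound 2 and compound 1 differ by methyl in place of hydrogen on a saturated chain carbon, two bonds along the chain from a nitrogen on an aromatic ring. The step is a 1.7-fold lower number from compound 1 to compound 2 (0.22 log units; within the scatter), so the two numbers cannot be told apart. Compound 3 stands apart from both: its number is lower than that of compound 2 and that of compound 1, and both gaps lie beyond the scatter. The difference between the core of compound 3 and the core of compound 1 is not broken down here.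

Compound 4 `C[C@@H](Nc1nc(O)c2cc(Cl)ccc2n1)c1ccccc1` has not been measured. It differs from compound 3 by methyl in place of hydrogen on a saturated chain carbon bound to an aromatic carbon and a nitrogen on an aromatic ring. Among the compounds with values here, this is the same kind of change as the one from compound 1 to compound 2, but the place is not the same: in compound 4 the methyl enters on a saturated chain carbon bound to an aromatic carbon and a nitrogen on an aromatic ring, whereas in compound 2 it enters on a saturated chain carbon two bonds along the chain from a nitrogen on an aromatic ring. Within the data shown here, the only measured pair carrying this kind of change gave a 1.7-fold lower number from compound 1 to compound 2 (0.22 log units; within the scatter), and there is no second pair to show whether the step repeats on the core of compound 3.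

From compound 3 to compound 4 a step of about a 1.5-fold lower number from compound 3 to compound 4 (0.17 log units; within the scatter) is expected in this assay, resting on the step from compound 1 to compound 2, a 1.7-fold lower number from compound 1 to compound 2 (0.22 log units; within the scatter), with wider bounds because the place differs. For compound 4 the estimate in this assay is 9000 nM, between 3500 nM and 23000 nM.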

Compound 4, half-maximal inhibitory concentration: 20200 nM
Compound 4: the middle estimate sits 2.2-fold (0.35 log units) below what was measured, and the stated range covers the measured number.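

In this assay, methyl in place of hydrogen on a saturated chain carbon bound to an aromatic carbon and a nitrogen on an aromatic ring gives a 1.5-fold higher number from compound 3 to compound 4 (0.18 log units; within the scatter), so the two numbers cannot be told apart. Set beside the earlier methyl step, this result gives no sign that the outcome depends on the core: the same change on two cores in this assay, a 1.7-fold lower number (0.22 log units; within the scatter) from compound 1 to compound 2 and a 1.5-fold higher number (0.18 log units; within the scatter) from compound 3 to compound 4, 2.5-fold (0.40 log units) apart, within the scatter of two such steps. This does not show that the step carries over unchanged from one core to another, as the methyl enters at a different place in each pair, and two steps that both lie within the scatter say nothing about how a step of clear size would transfer.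

Still open, from the compounds shown here alone, is whether a larger group at the same saturated chain carbon, such as ethyl or a longer chain, or a chain bearing an amine or a carboxylic acid, would move the number beyond the scatter on either core. Within the data shown here, also open is whether the mirror-image form of compound 4 would give a number that can be told apart from the one for compound 4.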